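A few compounds are considered here, and "the series" means these few. Any claim that something is new, unique, unknown or untested is made for them only; others in the source may bear on it.

Three compounds have been measured in a functional assay (brain) for displacement of a labelled ligand, with Rattus norvegicus as the target; a higher number here means a weaker inhibitor, a lower number a stronger inhibitor:
compound 1, `CC(C)[C@]1(c2ccccc2)OC[C@H]([C@@H]2CCCCN2)O1`, gives 45 nM;
compound 2, `CCCCCCCCC[C@]1(c2ccccc2)OC[C@H]([C@@H]2CCCCN2)O1`, gives 43000 nM;
compound 3, `CC[C@]1(c2cccc(Cl)c2)OC[C@H]([C@@H]2CCCCN2)O1`, gives 59 nM.

Among these three numbers compound 3 has the second highest. Its nearest neighbour is compound 1, whose number is lower by an amount that lies within the usual scatter of repeated measurements, so the two cannot be told apart. Compound 2 stands far away, with a number higher by an amount well beyond the scatter; it alone is clearly the weaker inhibitor of the three.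

Compound 4, `CC[C@]1(c2cccc(O)c2)OC[C@H]([C@@H]2CCCCN2)O1`, has not yet been measured. It differs from compound 3 in one place: hydroxy in place of chloro on an aromatic carbon. For the measured compounds named here, no step between two measured compounds follows this same exchange, so nothing measured here shows how a hydroxy in place of a chloro shifts the read-out. Compound 1, whose ring carries no substituent, gives a number within the scatter of compound 3, which hints that the ring substituent is not decisive on its own. The expected step from compound 3 to compound 4 is a 2.5-fold higher number from compound 3 to compound 4 (0.41 log units; beyond the scatter), a modest rise toward a weaker inhibitor, with a real chance that it stays within the scatter. Compound 4 is estimated at 150 nM, in the range from 40 nM to 600 nM.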

Compound 4, inhibition constant: 489 nM
The estimate for compound 4 lay 3.3-fold (0.51 log units) below the measured number; the range from low to high includes it.
By their numbers in this assay, from the lowest: compounds 1 and 3 (each within the scatter of the next); then compound 4; then compound 2.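

Hydroxy in place of chloro on this aromatic carbon gives an 8.3-fold higher number from compound 3 to compound 4 (0.92 log units; beyond the scatter) in this assay, a shift toward a weaker inhibitor that lies beyond the scatter. For the compounds shown here, no earlier pair of compounds isolated a change on the aromatic ring, so this is the first direct sign that this position is sensitive to which group it carries, with the rest of the molecule held constant. Nothing measured here explains the shift, so it cannot be said whether it comes from losing the chloro, gaining the hydroxy, or both.

The compounds shown leave open how other groups on this same carbon, such as methoxy, fluoro or an amine, would compare with chloro and hydroxy, and so whether hydroxy is unusually poor here or chloro is unusually good. They also leave open whether the same exchange would shift the number by a similar amount in a compound with isopropyl or a longer chain in place of the ethyl.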